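The source may report more compounds than this note shows. Statements on the series, on what has been measured and on what is new or still open speak of the compounds shown alone.

Measured in a functional assay on HCT-116 cells (Homo sapiens) for antiproliferative activity, read by MTT assay, with a stated time of 72 h; a higher number here means a weaker inhibitor, a lower number a stronger inhibitor:
compound 1 `O=C(NCc1ccccc1)c1csc(NC(=S)Nc2ccc(Cl)cc2)n1`: 62200 nM
compound 2 `O=C(NCCCc1ccccc1)c1csc(NC(=S)Nc2ccc(Cl)cc2)n1`: 36600 nM
compound 3 `CCOC(=O)c1csc2nc(CN3CCN(Cc4ccccc4)CC3)c(-c3ccc(C)cc3)n12`: 47800 nM

Compound 3, at 47800 nM, lies within the usual scatter of both compound 1 and compound 2, so these values cannot be ranked against it. Compound 4 `CCOC(=O)c1csc2nc(CN3CCN(Cc4ccccc4)CC3)c(-c3ccc(OC)cc3)n12` carries methoxy in place of methyl on an aromatic carbon, turning 4-methylphenyl into 4-methoxyphenyl: methoxy in place of methyl on an aromatic carbon. Going by the values given here, the only measured step, a 1.7-fold lower number from compound 1 to compound 2 (0.23 log units; within the scatter), concerns a chain in a different pair and stays within the scatter, so it bears only loosely on this swap. Among the compounds with values here, no measured pair tests this swap directly, so no shift beyond the scatter is expected in this assay. The estimated step is a 1.1-fold lower number from compound 3 to compound 4 (0.03 log units; within the scatter). For compound 4 the expected value is 45000 nM, within an estimated range of 20000 nM to 100000 nM.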

Compound 4, half-maximal inhibitory concentration: 19600 nM
For compound 4 the middle estimate is 2.3-fold (0.36 log units) above the measured one, and the stated range ends above it.
By their numbers in this assay, from the lowest: compounds 4, 2, 3 and 1 (each within the scatter of the next, the first and the last beyond it).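

In this assay, going by these compounds alone, the change from 4-methylphenyl to 4-methoxyphenyl gives a 2.4-fold lower number from compound 3 to compound 4 (0.39 log units; beyond the scatter) and so is the first step in this set to clear the usual scatter, though only modestly. This shows that the group para to a large group on this ring can influence antiproliferative activity, even when the change adds only one oxygen atom. No measurement shown here explains this shift.

Still open, on these data alone, is whether a hydroxyl, an amine or a longer ethoxy chain at this place would lower the number further or raise it again.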